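A few compounds are considered here, and "the series" means these few. Any claim that something is new, unique, unknown or untested is made for them only; others in the source may bear on it.

The measured compounds and their readings:

compound 1 `COc1ccc2c(=O)c(/C=C/C(=O)NCc3cccc(F)c3)coc2c1` — in an ADME assay on HepG2 2.2.15 cells (Homo sapiens) for cytotoxicity, read by MTT assay, with stated times of 48 h and 9 days (on this read-out higher numbers stand for lower toxicity in this test and lower numbers for higher toxicity in this test), compound 1 gives 475000 nM
compound 2 `COc1ccc2c(=O)c(/C=C/C(=O)Nc3ccc(Cl)cc3)coc2c1` — in this assay compound 2 gives 272000 nM
compound 3 `COc1ccc2c(=O)c(/C=C/C(=O)NCc3ccccc3)coc2c1` — in this assay compound 3 gives 376000 nM

Compound 3 stands second highest of the three numbers. Its nearest neighbour is compound 1, with a 1.3-fold lower number from compound 1 to compound 3 (0.10 log units; within the scatter); its furthest is compound 2, with a 1.4-fold higher number from compound 2 to compound 3 (0.14 log units; within the scatter). All three compounds therefore sit within the scatter of one another, and none can be called the most or least toxic.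

Compound 4 `COc1cccc(NC(=O)/C=C/c2coc3cc(OC)ccc3c2=O)c1` differs from compound 3 at the amide-type nitrogen: 3-methoxyphenyl in place of benzyl on an amide-type nitrogen. Within the data shown here, two measured steps bear on this kind of change, in which an aryl group stands in place of a benzyl group, or the reverse, on that nitrogen: a 1.7-fold lower number from compound 1 to compound 2 (0.24 log units; within the scatter) and a 1.4-fold higher number from compound 2 to compound 3 (0.14 log units; within the scatter). Both are within the scatter. Among the measured compounds shown here, the shift of a methoxy onto the entering ring has no measured counterpart here, so it is judged only by analogy to these steps. A step of a 1.1-fold lower number from compound 3 to compound 4 (0.03 log units; within the scatter) is therefore expected, that is, none beyond the scatter. For compound 4 the estimate in this assay is 350000 nM, with a range from 180000 nM to 700000 nM.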

Compound 4, half-maximal cytotoxic concentration: 1130000 nM
For compound 4 the middle estimate is 3.2-fold (0.51 log units) below the measured one; measured number outside the range, above it.
By their numbers in this assay, from the lowest: compounds 2, 3 and 1 (each within the scatter of the next); then compound 4.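

Among these compounds, compound 4 gives the first steps at the amide-type nitrogen that lie beyond the scatter in this assay: a 3.0-fold higher number from compound 3 to compound 4 (0.48 log units; beyond the scatter), a 4.2-fold higher number from compound 2 to compound 4 (0.62 log units; beyond the scatter) and a 2.4-fold higher number from compound 1 to compound 4 (0.38 log units; beyond the scatter). The group on this nitrogen can therefore shift this read-out towards lower toxicity in this test, although all three steps are modest. An aryl group in place of benzyl is not enough on its own, since compound 2, with 4-chlorophenyl, stays within the scatter of compound 3. No measurement shown here accounts for the size of these steps.

The compounds shown leave open whether the methoxy group itself matters, and whether a hydroxy group or an amine on the same ring would give a similar number. They also leave open how a methoxy group on the benzyl ring of compound 3 would read.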